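The compounds below may be only part of what the source reports. "The series", "measured", "known", "first", "only" and "open" are said of these compounds alone.

Compound 2 `O=C(c1cc[nH]n1)N1CCC(C(=O)N2N=CCC2c2ccccc2)CC1` carries a (1H-pyrazol-3-yl)carbonyl on the amine nitrogen in the ring where compound 1 `O=C(C1CCN(c2ccccc2)CC1)N1N=CCC1c1ccccc1` carries a phenyl. In an ADME assay on microsomes (Homo sapiens) for metabolic stability (on this read-out lower numbers stand for a shorter-lived compound and higher numbers for a longer-lived compound), compound 1 gives > 1.5 h, which is a limit of the assay and not a number. In this assay compound 2 gives > 2.75 h, again a limit rather than a number. The step that the two limits leave unreadable from compound 1 to compound 2 therefore cannot be read in size; both values shown for the series sit at limits, the limit of > 1.5 h in this assay, at which 1 of the 2 values shown sits, and (the limit of > 2.75 h in this assay, at which 1 of the 2 values shown sits), so compound 2 stands at a limit with no measured number around it. Compound 3 `O=C(c1cocn1)N1CCC(C(=O)N2N=CCC2c2ccccc2)CC1` differs from compound 2 by 1,3-oxazol-4-yl in place of 1H-pyrazol-3-yl on a carbonyl carbon. For the measured compounds named here, no measured step bears on this change: the one measured step is unreadable in size and concerns a different place in the molecule. The expected step is an at least 1.1-fold lower number from compound 2 to compound 3 (0.04 log units; that floor lies within the scatter), with no direction that can be supported. This expectation rests on compound 2 standing at > 2.75 h. For compound 3 the estimate in this assay is 2.5 h, within 1 h to 5 h.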

Compound 3, half-life: > 2.75 h
Compound 3: a limit, no number; the forecaster's own chance of this, stated with the estimate: 50%; middle value at least 1.1-fold (0.04 log units) away from the limit.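

In this assay compound 3 gives > 2.75 h, a limit and not a number. The steps among compound 1, compound 2 and compound 3 therefore cannot be read in size. Still open, from the compounds shown here alone, is how far the half-life of each of the three compounds lies beyond its limit, and so whether 1,3-oxazol-4-yl and 1H-pyrazol-3-yl differ at all on this read-out.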